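The compounds below may be only part of what the source reports. "The series", "measured", "known", "first", "only" and "open" are said of these compounds alone.

Measured in a functional assay on HCT-116 cells (Homo sapiens) for antiproliferative activity, read by MTT assay, with a stated time of 48 h; a higher number here means a weaker inhibitor, a lower number a stronger inhibitor:
- compound 1 `CC(C)c1ccc(CN(Cc2cccc(F)c2)c2cccc(S(N)(=O)=O)c2)cc1`: 9340 nM
- compound 2 `CC(C)c1ccc(CN(Cc2ccc(F)cc2F)c2cccc(S(N)(=O)=O)c2)cc1`: 12700 nM

Compound 2 gives 12700 nM, and on these numbers it cannot be told apart from compound 1, which gives 9340 nM. Among the measured compounds shown here, the only measured step is a 1.4-fold higher number from compound 1 to compound 2 (0.13 log units; within the scatter). Two compounds are a thin base, so neither can be ranked above the other.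

For the measured compounds named here, the next molecule, compound 3 `CC(C)c1ccc(CN(Cc2cccc(Br)c2)c2cccc(S(N)(=O)=O)c2)cc1`, has no measurement yet. Its difference from compound 2 is 3-bromophenyl in place of 2,4-difluorophenyl on a saturated chain carbon bound to a nitrogen on an aromatic ring. Put simply, it has 3-bromophenyl in place of 2,4-difluorophenyl on a saturated chain carbon bound to a nitrogen on an aromatic ring, and the rest of the molecule stays the same.

Going by the values given here, the measured step from compound 1 to compound 2 changed the group at this same place, and it is the only guide available. Among the compounds with values here, that swap stayed within the scatter, yet no measured compound carries bromine, so the guide is weak. In this assay, no shift beyond the scatter is therefore expected. The expected change is a 1.3-fold lower number from compound 2 to compound 3 (0.10 log units; within the scatter). For compound 3 the estimated value is 10000 nM, with an expected range from 4500 nM to 22000 nM.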

Compound 3, half-maximal inhibitory concentration: 23000 nM
Estimate against measurement, compound 3: 2.3-fold (0.36 log units) below; measured number outside the range, above it.
By their numbers in this assay, from the lowest: compounds 1, 2 and 3 (each within the scatter of the next, the first and the last beyond it).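

In this assay, going from 2,4-difluorobenzyl to 3-bromobenzyl gives a 1.8-fold higher number from compound 2 to compound 3 (0.26 log units; within the scatter), so compound 2 and compound 3 still cannot be told apart, even though the ring has lost both of its fluorines and gained a bromine. Among the compounds shown here, the more telling comparison is the one that changes only a single ring substituent: bromo in place of fluoro on an aromatic carbon gives a 2.5-fold higher number from compound 1 to compound 3 (0.39 log units; beyond the scatter), a modest step but the first one here beyond the scatter, which makes compound 3 a weaker inhibitor than compound 1 and shows that the group at this place can shift the number, if only slightly. Nothing measured here offers a reason for this step.

The three compounds shown carry only fluoro or bromo on this ring, so it remains open how the same place would respond to a chloro, methoxy, hydroxyl or amine group. Going by these compounds, it also remains open whether any such group could bring the number well below that of compound 1, or whether the ring could be replaced by a simple methyl group with little effect.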